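Aryl swap on the ring nitrogen: expectation for compound 4

The source may report more compounds than this note shows. Statements on the series, on what has been measured and on what is new or still open speak of the compounds shown alone.

Measured in a functional assay on MCF7 cells (Homo sapiens) for cytotoxicity, read by MTT assay, with a stated time of 72 h; a higher number here means a weaker inhibitor, a lower number a stronger inhibitor:
compound 1, `CNC(=O)c1cc(Oc2ccc(NC(=O)c3nn(-c4ccc(Br)cc4F)c(=O)cc3C)cc2F)ccn1`: 9360 nM
compound 2, `CNC(=O)c1cc(Oc2ccc(NC(=O)c3nn(-c4ccc(C)cc4)c(=O)cc3C)cc2F)ccn1`: 8380 nM
compound 3, `Cc1cc(=O)n(-c2ccccc2C(F)(F)F)nc1C(=O)Nc1ccc(Oc2ncnc3ccsc23)cc1`: 5550 nM

Compound 3 gives the lowest of the three numbers, but its gaps to compound 2 and to compound 1 are both within the scatter, so no order among the three is claimed.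

Compound 4, `Cc1cc(=O)n(-c2ccc(F)c(F)c2)nc1C(=O)Nc1ccc(Oc2ncnc3ccsc23)cc1`, differs from compound 3 by 3,4-difluorophenyl in place of 2-(trifluoromethyl)phenyl on an aromatic nitrogen. Among the measured compounds shown here, the only measured step at the same place is a 1.1-fold lower number from compound 1 to compound 2 (0.05 log units; within the scatter), which stayed within the scatter. For the measured compounds named here, no measured step bears on the 2-(trifluoromethyl)phenyl group or on the 3,4-difluorophenyl group; the closest information is that swap on the aromatic nitrogen, and it did not move the number. The step of a 1.0-fold lower number from compound 3 to compound 4 (0.00 log units; within the scatter) is therefore expected to be small, with no direction beyond the scatter.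

Compound 4 is estimated at 5500 nM in this assay, with a range from 2500 nM to 12000 nM.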

Compound 4, half-maximal inhibitory concentration: 5550 nM
The estimate for compound 4 lay 1.0-fold (0.00 log units) below the measured number; the measured number falls inside the stated range.
By their numbers in this assay, from the lowest: compounds 3, 4, 2 and 1 (each within the scatter of the next).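

In this assay, no change at the digits printed from compound 3 to compound 4 (within the scatter) shows that a second aryl exchange on the aromatic nitrogen also stays within the scatter, this time on the core of compound 3 rather than the core of compound 1. This exchange replaces 2-(trifluoromethyl)phenyl with 3,4-difluorophenyl, so the substitution on the aryl ring differs as well as the heavy-atom count, yet both steps at this position remain within the scatter. No available measurement offers an explanation for this result.

On these data alone, it remains open whether any group on this nitrogen can move the number beyond the scatter, for example a phenyl ring carrying an amine or a carboxylic acid, or a longer alkyl chain in place of the aryl ring. The core of compound 1 and the core of compound 3 also cannot be compared, as no pair shown differs only there.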